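Notes: benzyl change from compound 1 to compound 4

The source may report more compounds than this note shows. Statements on the series, on what has been measured and on what is new or still open speak of the compounds shown alone.

Measured in a functional assay on A549 cells (Homo sapiens) for inhibition, read by MTT assay, with a stated time of 72 h; on this read-out higher numbers stand for weaker inhibition and lower numbers for stronger inhibition:
compound 1 `CCc1nc2c(C)cc(-c3ccc(CN4CCN(C)CC4)cc3)cn2c1NC(=O)OCc1cc(Cl)cc(Cl)c1`: 4020 nM
compound 2 `CCc1nc2c(C)cc(-c3ccc(CN4CCC(C)CC4)cc3)cn2c1NC(=O)OCc1cc(Cl)cc(Cl)c1`: 8180 nM
compound 3 `CCc1nc2c(C)cc(-c3ccc(CNCCO)cc3)cn2c1NC(=O)OCc1cc(Cl)cc(Cl)c1`: > 20000 nM (a limit)

Compound 1 has the lower of the two numeric values, and its nearest neighbour gives a 2.0-fold higher number from compound 1 to compound 2 (0.31 log units; beyond the scatter). The value of compound 3 is a limit of the assay.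

The next compound is compound 4 `CCc1nc2c(C)cc(-c3ccc(CN4CCN(C)CC4)cc3)cn2c1NC(=O)OCc1ccc(C(F)(F)F)cc1`, with 4-(trifluoromethyl)phenyl in place of 3,5-dichlorophenyl on a saturated chain carbon bound to an oxygen next to a carbonyl group. Within the data shown here, no measured step touches this place. The steps of a 2.0-fold higher number from compound 1 to compound 2 (0.31 log units; beyond the scatter), an at least 4.9-fold higher number from compound 1 to compound 3 (0.69 log units; beyond the scatter) and an at least 2.4-fold higher number from compound 2 to compound 3 (0.38 log units; beyond the scatter) all change the group on a saturated chain carbon bound to an aromatic carbon. They show how far the numbers have moved at that other place, but they give no direction for this change. No step beyond the scatter is therefore expected in this assay, with a wide margin either way. The estimated change is a 1.1-fold higher number from compound 1 to compound 4 (0.05 log units; within the scatter). For compound 4 the estimate is 4500 nM, with an expected range of 1500 nM to 14000 nM.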

Compound 4, half-maximal inhibitory concentration: > 20000 nM
Compound 4: no number, only a limit; the forecaster's own chance of this, stated with the estimate: 10%; middle value at least 4.4-fold (0.64 log units) away from the limit.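

This place responds to the change: in this assay, 4-(trifluoromethyl)phenyl in place of 3,5-dichlorophenyl gives an at least 4.9-fold higher number from compound 1 to compound 4 (0.69 log units; beyond the scatter), towards weaker inhibition. Until now, every step lay at the group on the saturated chain carbon bound to an aromatic carbon; compound 4 keeps the 4-methylpiperazin-1-yl group, so this step belongs to the other end of the molecule alone. The full size of the step cannot be read, as compound 4 gives only a limit of the assay: the limit of > 20000 nM in this assay, at which 2 of the 4 values shown sit.

Going by these compounds, with two groups compared here, it remains open whether the chlorine atoms, their number or the trifluoromethyl group drives the step, and 4-chlorophenyl or 3,5-bis(trifluoromethyl)phenyl would help separate these. On these data alone, it is also open whether the step holds alongside 4-methylpiperidin-1-yl.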